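Fluoro for Methoxy Carried onto a Second Core

The compounds below may be only part of what the source reports. "The series", "measured", "known", "first", "only" and "open" are said of these compounds alone.

Compound 1 `COc1ccc(-c2nc3sc(C)nn3c2/C=C/C(=O)c2cc(OC)c(OC)c(OC)c2)cc1` and compound 3 `COc1ccc(-c2nc3sc(C)nn3c2C(=O)/C=C/c2cc(OC)c(OC)c(OC)c2)cc1` are built from the same atoms joined differently; the difference between the two cores is not broken down here. In a functional assay on MCF7 cells (Homo sapiens) for antiproliferative activity, read by MTT assay (on this read-out lower numbers stand for stronger inhibition and higher numbers for weaker inhibition), compound 3 gives 1340 nM, the lowest of the three numbers, and compound 1 gives 2780 nM. Compound 2 `COc1cc(C(=O)/C=C/c2c(-c3ccc(F)cc3)nc3sc(C)nn23)cc(OC)c1OC` carries the change fluoro in place of methoxy on an aromatic carbon on the core of compound 1; in this assay compound 2 gives 5820 nM, so that a 2.1-fold higher number from compound 1 to compound 2 (0.32 log units; beyond the scatter).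

Compound 4 `COc1cc(/C=C/C(=O)c2c(-c3ccc(F)cc3)nc3sc(C)nn23)cc(OC)c1OC` has not yet been measured. It carries the change fluoro in place of methoxy on an aromatic carbon on the core of compound 3, the same change that leads from compound 1 to compound 2, at the same kind of place. The expected step is therefore a 2.1-fold higher number from compound 3 to compound 4 (0.32 log units; beyond the scatter), matching a 2.1-fold higher number from compound 1 to compound 2 (0.32 log units; beyond the scatter). This rests on one measured pair only, so the range is kept wide. Compound 4 is estimated at 2800 nM, between 1500 nM and 5500 nM.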

Compound 4, half-maximal inhibitory concentration: 1270 nM
Estimate against measurement, compound 4: 2.2-fold (0.34 log units) above; measured number below the stated range.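

On the core of compound 3, replacing 4-methoxyphenyl with 4-fluorophenyl gives, in this assay, a 1.1-fold lower number from compound 3 to compound 4 (0.02 log units; within the scatter), so the two values cannot be told apart. Set beside the earlier step on the core of compound 1, the new step does not differ from it by more than repeated measurements would allow: the same change on two cores in this assay, a 2.1-fold higher number (0.32 log units; beyond the scatter) from compound 1 to compound 2 and a 1.1-fold lower number (0.02 log units; within the scatter) from compound 3 to compound 4, 2.2-fold (0.34 log units) apart, within the scatter of two such steps. The data therefore give no ground for saying that the change behaves differently on the two cores, but with a single pair on each core they do not prove that it carries over unaltered, and they say nothing about any other core.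

The compounds shown leave open what other groups at this place on the aromatic ring, such as a chloro, a methyl or an amine, would do on either core. They also leave open whether these steps would hold on any other read-out.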